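Three inactive adenine derivatives and a fourth awaiting test

The source may hold more compounds than are shown below. What is called first, only, known or untested is meant among the compounds shown, and "the series" means these compounds.

The measured compounds:
Compound 1 `COc1ccccc1CNc1ncnc2c1ncn2C1CCCCO1`. In an ADME assay on MCF7 cells (Homo sapiens) for cytotoxicity, with a stated time of 72 h (on this read-out higher numbers stand for weaker inhibition and lower numbers for stronger inhibition), compound 1 gives > 100000 nM, which is a limit of the assay rather than a number.
Compound 2 `COc1cccc(OC)c1CNc1ncnc2c1ncn2C1CCCCO1`. In this assay compound 2 gives > 100000 nM, again a limit of the assay.
Compound 3 `COc1cc(CNc2ncnc3c2ncn3C2CCCO2)cc(OC)c1`. In this assay compound 3 gives > 100000 nM, also a limit of the assay.

Compound 1 and compound 2 differ in one place, (methoxy in place of hydrogen on an aromatic carbon). From the compounds shown here alone, because both values sit at a limit, the step that the two limits leave unreadable from compound 1 to compound 2 cannot be read; its size is unknown. The difference between the core of compound 1 and the core of compound 3 is not broken down here; only their two values can be set side by side, and both are limits.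

Compound 4 `COc1cc(CNc2ncnc3c2ncn3C2CCCO2)cc(OC)c1OC` has not yet been measured. It differs from compound 3 by methoxy in place of hydrogen on an aromatic carbon. For the measured compounds named here, this is the same kind of change as the one from compound 1 to compound 2, but not the same: in compound 2 the entering methoxy sits ortho to a large group and meta to a methoxy group, whereas in compound 4 it sits ortho to two methoxy groups and para to a large group.

Going by the values given here, the only evidence available is the limit of > 100000 nM in this assay, at which 3 of the 3 values shown sit, with every value at the limit. The step that the limit leaves unreadable from compound 3 to compound 4 is therefore expected to be small, resting on compound 3 at > 100000 nM and on the unreadable step from compound 1 to compound 2. Compound 4 is expected to give about 150000 nM, most likely again as a limit, with a range from 40000 nM to 600000 nM.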

Compound 4, half-maximal inhibitory concentration: > 100000 nM
Compound 4: only a limit was reported (the forecaster's own chance of this, stated with the estimate: 85%); the middle value is on the limit's open side.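

In this assay compound 4 gives > 100000 nM, which is a limit of the assay rather than a number. Compound 3 also stands at a limit, so no size can be read for the step between compound 3 and compound 4. The compounds shown leave open how strongly any of them acts on these cells, or whether the added methoxy changes that at all, because all the results share one ceiling: the limit of > 100000 nM in this assay, at which 4 of the 4 values shown sit.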